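The compounds below may be only part of what the source reports. "The series", "measured", "known", "first", "only" and "open" are said of these compounds alone.

Measured in a functional assay on the whole organism (strain Kunming) with Mus musculus as the target, with a stated time of 0.5 h; a lower number here means that less compound is needed, a higher number that more compound is needed for the effect:
- compound 1 `COc1cc(OC)c(OC)cc1/C=C/COC(=O)/C=C/c1ccc(OC)c(OC)c1`: 140 umol/kg
- compound 2 `COc1cc(OC)c(OC)cc1/C=C/COC(=O)/C=C/c1ccc(Br)cc1`: 143 umol/kg

Among the measured compounds shown here, compound 1 stands level with compound 2, the only other measured compound, as the two values lie within the scatter of each other. The next compound to read is compound 3 `COc1cc(OC)c(OC)cc1/C=C/COC(=O)/C=C/c1cc(OC)c(OC)c(OC)c1`, which has methoxy in place of hydrogen on an aromatic carbon.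

For the measured compounds named here, one measured step bears on this change. With 4-bromophenyl in place of 3,4-dimethoxyphenyl, the step is a 1.0-fold higher number from compound 1 to compound 2 (0.01 log units; within the scatter), so even this larger exchange of substituents stays within the scatter. Going by the values given here, this is thin evidence, as no measured pair shows an added methoxy alone. No shift beyond the scatter is expected in this assay, in either direction, and the estimated step is no change at the digits printed from compound 1 to compound 3 (within the scatter). For compound 3 the expected value is 140 umol/kg, with an estimated range of 70 umol/kg to 280 umol/kg.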

Compound 3, dose for half-maximal effect: 74.7 umol/kg
The estimate for compound 3 lay 1.9-fold (0.27 log units) above the measured number; measured number inside the range.
By their numbers in this assay, from the lowest: compounds 3, 1 and 2 (each within the scatter of the next).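

In this assay, among the compounds shown here, methoxy in place of hydrogen on an aromatic carbon, ortho to a methoxy group and meta to a large group, gives a 1.9-fold lower number from compound 1 to compound 3 (0.27 log units; within the scatter) and is the only measured step that isolates this addition. The earlier pair exchanged whole substituted aryl groups, whereas this step shows that a single added methoxy at this position also leaves the number within the scatter. No measurement on hand speaks to the cause of this step.

Still open, going by these compounds, is whether an amine, a carboxylic acid or a longer alkoxy chain in place of the same hydrogen would move the number beyond the scatter. Equally open, on these data alone, is whether an amide in place of the ester link would change the number in this assay at all.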